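This account rests on a few compounds, and the source may have more. Where it says the series, first, only, none or still open, it means among the compounds named here.

Measured in a functional assay on HepG2 cells (Homo sapiens) for cytotoxicity, read by MTT assay, with a stated time of 24 h; a higher number here means a weaker inhibitor, a lower number a stronger inhibitor:
- compound 1 `CN1C/C(=C\c2ccc(C#N)cc2)C(=O)/C(=C/c2ccccc2F)C1`: 590 nM
- compound 2 `COc1cc(/C=C2\CN(C)C/C(=C\c3ccc(Cl)cc3)C2=O)cc(OC)c1`: 5950 nM
- compound 3 `COc1cc(/C=C2\CN(C)C/C(=C\c3ccc(Cl)cc3)C2=O)cc(OC)c1OC`: 8250 nM

In this assay, compound 3 at 8250 nM cannot be separated from compound 2, and both values are well above that of compound 1. The next compound is compound 4 `COc1cc(/C=C2\CN(C)C/C(=C\c3ccc(C#N)cc3)C2=O)cc(OC)c1OC`, which turns the 4-chlorophenyl of compound 3 into 4-cyanophenyl: cyano in place of chloro on an aromatic carbon. The change sits on an aromatic carbon of a six-membered aromatic ring of carbon only, para to a large group.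

Among the compounds with values here, no measured step covers this exchange. Within the data shown here, the one step available, a 1.4-fold higher number from compound 2 to compound 3 (0.14 log units; within the scatter), is methoxy in place of hydrogen on the other aromatic ring, and it stays within the scatter. It suggests only that the added methoxy need not shift the number much. Among the measured compounds shown here, the sole measured compound with a cyano group is compound 1 at 590 nM, but it also differs from compound 3 on the other ring, so it supports only a cautious move toward a lower number. The expected change is a 2.8-fold lower number from compound 3 to compound 4 (0.44 log units; beyond the scatter), and it remains uncertain. For compound 4 the estimated value is 3000 nM, with an expected range of 800 nM to 9000 nM.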

Compound 4, half-maximal inhibitory concentration: 1140 nM
For compound 4 the middle estimate is 2.6-fold (0.42 log units) above the measured one; the range from low to high includes it.
By their numbers in this assay, from the lowest: compounds 1 and 4 (each within the scatter of the next); then compounds 2 and 3 (each within the scatter of the next).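

In this assay, the exchange of 4-chlorophenyl for 4-cyanophenyl gives a 7.2-fold lower number from compound 3 to compound 4 (0.86 log units; beyond the scatter) and so moves the number beyond the scatter, whereas the methoxy step on the other aromatic ring (a 1.4-fold higher number from compound 2 to compound 3 (0.14 log units; within the scatter)) stayed within it. This aromatic carbon, para to a large group, is therefore a place where the group carried can change the number in this assay, at least with the rest of compound 3 held constant. Nothing measured here bears on why cyano and chloro differ in this way.

Going by these compounds, this exchange rests on one matched pair, so whether the same step holds with the other ring of compound 2 or of compound 1 remains open. Only chloro and cyano appear at this position among the compounds shown, which leaves open how the number would respond to an amine, a carboxylic acid or a longer chain such as a propyl group there.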